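A Trifluoromethyl Swap Carried onto a Second Core

A few compounds are considered here, and "the series" means these few. Any claim that something is new, unique, unknown or untested is made for them only; others in the source may bear on it.

Compound 1 `Nc1ccc2oc(-c3cccc(F)c3)cc(=O)c2c1` and compound 2 `Nc1ccc2oc(-c3cccc(C(F)(F)F)c3)cc(=O)c2c1` share one core and differ in a single place: trifluoromethyl in place of fluoro on an aromatic carbon. In an ADME assay on MT4 cells (Homo sapiens) for cytotoxicity, read by MTT assay, with a stated time of 4 days (a lower number here means that less compound is tolerated, a higher number that more compound is tolerated), compound 1 gives 269000 nM, and compound 2 gives 138000 nM. That change produced a step of a 1.9-fold lower number from compound 1 to compound 2 (0.29 log units; within the scatter), so the two numbers cannot be told apart with confidence.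

Compound 3 `CC(=O)Nc1ccc2oc(-c3cccc(F)c3)c(O)c(=O)c2c1` is built on a different core; the difference between the two cores is not broken down here. In this assay compound 3 gives 26500 nM, the lowest of the three numbers, and its distance from compound 2 as well as from compound 1 lies beyond the scatter.

Compound 4 `CC(=O)Nc1ccc2oc(-c3cccc(C(F)(F)F)c3)c(O)c(=O)c2c1` has not been measured. It differs from compound 3 by trifluoromethyl in place of fluoro on an aromatic carbon. The place of this change reads the same, word for word, as the place of the change from compound 1 to compound 2, so it is the same change carried onto the core of compound 3.

The expectation rests on one observation: the same change gave a 1.9-fold lower number from compound 1 to compound 2 (0.29 log units; within the scatter), a move that stayed within the scatter. On that basis a step of a 1.5-fold lower number from compound 3 to compound 4 (0.17 log units; within the scatter) is expected in this assay. Compound 4 is therefore estimated at 18000 nM, with the likely range spanning 8000 nM to 45000 nM.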

Compound 4, half-maximal cytotoxic concentration: 5700 nM
Compound 4: the middle estimate sits 3.2-fold (0.50 log units) above what was measured, and the stated range ends above it.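

In this assay, trifluoromethyl in place of fluoro on the core of compound 3 gives a 4.6-fold lower number from compound 3 to compound 4 (0.67 log units; beyond the scatter), so on this core the change separates the two compounds clearly. Set beside the same change on the core of compound 1, this step cannot be told apart from the earlier one: the same change on two cores in this assay, a 1.9-fold lower number (0.29 log units; within the scatter) from compound 1 to compound 2 and a 4.6-fold lower number (0.67 log units; beyond the scatter) from compound 3 to compound 4, 2.4-fold (0.38 log units) apart, within the scatter of two such steps The result is therefore compatible with the change carrying over from one core to the other in this assay, but it does not show that the second core responds more strongly, even though only its step lies beyond the scatter, and one pair on each of two cores gives no general rule for the series.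

The compounds shown hold only fluoro and trifluoromethyl at this place, so whether a chloro group, a methoxy group or a nitrile would behave in the same way stays open. Also open, from the compounds shown here alone, is how the change would behave on a core carrying only one of the two features that set compound 3 apart from compound 1, the acetyl group on the amine and the hydroxyl group.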